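Acylisoimidourea series: methylsulfanyl in place of benzylselanyl

The compounds below may be only part of what the source reports. "The series", "measured", "known", "first", "only" and "open" are said of these compounds alone.

Working notes on the series. Three compounds have numbers in a functional assay on K562 cells (Homo sapiens) for cytotoxicity, read by MTT assay, with a stated time of 72 h; a higher number here means a weaker inhibitor of growth, a lower number a stronger inhibitor of growth. Compound 1 `CS/C(=N\C(=O)c1csc([N+](=O)[O-])c1)NC(=O)c1csc([N+](=O)[O-])c1` gives 98700 nM. Compound 2 `O=C(/N=C(/NC(=O)c1cc(-c2ccccc2)nc2ccccc12)[Se]Cc1ccccc1)c1cc(-c2ccccc2)nc2ccccc12` gives 47400 nM. Compound 3 `O=C(/N=C(/NC(=O)c1cccs1)[Se]Cc1ccccc1)c1cccs1` gives 58500 nM. Compound 2 has the lowest of the three numbers; its gap to compound 3 is within the scatter, so no order between those two is claimed, while its gap to compound 1 lies beyond the scatter. Among the compounds with values here, no pair of measured compounds differs in only one place, so no single step has been measured yet.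

Compound 4 `CS/C(=N\C(=O)c1cc(-c2ccccc2)nc2ccccc12)NC(=O)c1cc(-c2ccccc2)nc2ccccc12` is the next compound. It differs from compound 2 in one place: a group of 2 heavy atoms (1 carbon, 1 sulfur; no ring) in place of a group of 8 heavy atoms (7 carbon, 1 selenium; one six-membered aromatic ring of carbon only), on a carbon with a double bond to nitrogen. Compound 1 carries the same methylsulfanyl group on a different core, and its number in this assay stands above that of compound 2 beyond the scatter, but the core also changes, so the exchange alone cannot be read from it. A moderate rise in the number, of about the usual scatter or a little more, is expected for compound 4. The estimated value for compound 4 is 75000 nM, with a range from 30000 nM to 180000 nM. The expected step is a 1.6-fold higher number from compound 2 to compound 4 (0.20 log units; within the scatter).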

Compound 4, concentration for total growth inhibition: > 100000 nM
Compound 4 ended at the assay's limit; the forecaster's own chance of this, stated with the estimate: 15%; middle value at least 1.3-fold (0.12 log units) from the limit.
By their numbers in this assay, from the lowest: compounds 2, 3 and 1 (each within the scatter of the next, the first and the last beyond it). At a limit, above all of these: compound 4.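

In this assay, within the data shown here, methylsulfanyl in place of the selenium-bearing group of 8 heavy atoms, on a carbon with a double bond to nitrogen, gives the first single step: an at least 2.1-fold higher number from compound 2 to compound 4 (0.32 log units; beyond the scatter). Compound 4 stands at > 100000 nM, which is a limit of the assay and not a number. The step therefore shows that this position is not indifferent to the exchange on this shared core, but it fixes only a lower bound on the size of the change: the limit of > 100000 nM in this assay, at which 1 of the 4 values shown sits.

The exchange removes the selenium and the aromatic ring together, so the compounds shown leave open which of the two goes with the step; a methylselanyl or a benzylsulfanyl group at this carbon would separate them. On these data alone, whether the step holds on other cores also remains open.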